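Azole swap at the acetamide methylene of the series

The source may hold more compounds than are shown below. What is called first, only, known or untested is meant among the compounds shown, and "the series" means these compounds.

Compound 3 `CCOc1ncc(-c2nc(C(F)(F)F)sc2N2CCN(C(=O)Cn3nccc3C)[C@H](C)C2)cn1` gives the highest number of the three measured in a functional assay on U2OS cells for antagonist activity at C-X-C chemokine receptor type 3 (Homo sapiens), read by beta-arrestin recruitment (a lower number here means a stronger inhibitor, a higher number a weaker inhibitor), 162 nM. Compound 1 `CCOc1ncc(-c2nc(C(F)(F)F)sc2N2CCN(C(=O)Cn3cnc4ccccc43)[C@H](C)C2)cn1` gives 49 nM and compound 2 `CCOc1ncc(-c2nc(C(F)(F)F)sc2N2CCN(C(=O)Cn3ccc4cccnc43)[C@H](C)C2)cn1` gives 47 nM; the step of a 1.0-fold lower number from compound 1 to compound 2 (0.02 log units; within the scatter) lies within the scatter, whereas a 3.3-fold higher number from compound 1 to compound 3 (0.52 log units; beyond the scatter) and a 3.4-fold higher number from compound 2 to compound 3 (0.54 log units; beyond the scatter) are both modest losses. Compound 4 `CCOc1ncc(-c2nc(C(F)(F)F)sc2N2CCN(C(=O)Cn3nc(C)nc3C)[C@H](C)C2)cn1` carries 3,5-dimethyl-1H-1,2,4-triazol-1-yl in place of 5-methyl-1H-pyrazol-1-yl on a saturated chain carbon bound to a carbonyl carbon. Within the data shown here, no measured step exchanges one small azole for another; the two steps onto the pyrazole show only that the smaller group reads modestly weaker than either larger one. Among the measured compounds shown here, there is no precedent for this change, so for compound 4 in this assay the expected step of a 1.1-fold higher number from compound 3 to compound 4 (0.05 log units; within the scatter) is none beyond the scatter. Compound 4 is estimated at 180 nM, range 80 nM to 420 nM.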

Compound 4, half-maximal inhibitory concentration: 173 nM
The estimate for compound 4 lay 1.0-fold (0.02 log units) above the measured number; measured number inside the range.
By their numbers in this assay, from the lowest: compounds 2 and 1 (each within the scatter of the next); then compounds 3 and 4 (each within the scatter of the next).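

In this assay, among these compounds, the first exchange of one small azole for another changes nothing beyond the scatter (a 1.1-fold higher number from compound 3 to compound 4 (0.03 log units; within the scatter)), so 3,5-dimethyl-1H-1,2,4-triazol-1-yl and 5-methyl-1H-pyrazol-1-yl cannot be told apart at this position. The triazole also remains modestly weaker than the two larger groups (a 3.5-fold higher number from compound 1 to compound 4 (0.55 log units; beyond the scatter); a 3.7-fold higher number from compound 2 to compound 4 (0.57 log units; beyond the scatter)), so the gap seen with the pyrazole holds for a second small azole. Nothing available explains these readings.

Still open, going by these compounds, is whether the methyl groups contribute at all, which unsubstituted 1H-pyrazol-1-yl would test. Also open, on these data alone, is whether a longer chain carrying the azole, or a carboxylic acid on it, would recover the level of compound 1 and compound 2.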